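Methoxy removal from compound 1: working notes

The source may report more compounds than this note shows. Statements on the series, on what has been measured and on what is new or still open speak of the compounds shown alone.

Measured so far in a functional assay on PC-3 cells (Homo sapiens) for cytotoxicity, read by MTT assay, with a stated time of 72 h (a lower number here means a stronger inhibitor, a higher number a weaker inhibitor), are two compounds
- compound 1 `COc1cc(/C=C/COC(=O)/C=C/c2cc(OC)c(OC)c(OC)c2)cc(OC)c1OC` gives 189000 nM
- compound 2 `COCOc1ccc(/C=C/C(=O)OC/C=C/c2ccc(OC)cc2)cc1` gives 226000 nM

The two values lie within the scatter of each other, so compound 1 stands level with compound 2 and no order can be drawn between them. Compound 3 `COc1ccc(/C=C/COC(=O)/C=C/c2cc(OC)c(OC)c(OC)c2)cc1OC` has hydrogen in place of methoxy on an aromatic carbon of compound 1 hydrogen in place of methoxy on an aromatic carbon and this carbon is ortho to a methoxy group and meta to a large group. No measured pair isolates this change, so its size in this assay is not shown directly. No step beyond the scatter is expected, an expectation that rests only on compound 2 (226000 nM) lying level with compound 1 (189000 nM) despite their differing structures. The estimated move is a 1.1-fold higher number from compound 1 to compound 3 (0.02 log units; within the scatter) and is expected to stay within the scatter. Compound 3 is expected at 200000 nM within an estimated range of 90000 nM to 450000 nM and its measurement is still to come.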

Compound 3, half-maximal inhibitory concentration: 80000 nM
Compound 3: the middle estimate sits 2.5-fold (0.40 log units) above what was measured, and the stated range ends above it.
By their numbers in this assay, from the lowest: compound 3; then compounds 1 and 2 (each within the scatter of the next).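

In this assay, hydrogen in place of methoxy on this aromatic carbon, ortho to a methoxy group and meta to a large group, gives a 2.4-fold lower number from compound 1 to compound 3 (0.37 log units; beyond the scatter) as a modest step, the first sign that the series responds to a change at this position. Methoxy is therefore not required here for the read-out, and its loss moves the number in the favourable direction, with compound 3 at 80000 nM. Nothing available bears on why the step occurs.

Going by these compounds, whether hydrogen is itself the better substituent here, or whether fluorine, a hydroxyl group or an amine on the same carbon would give a similar number, remains open. Also open, on these data alone, is whether removing a methoxy group elsewhere on the core of compound 1 would move the number the same way.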